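Furan-2-yl in place of 4-chlorophenyl on the furoxan amide

A few compounds are considered here, and "the series" means these few. Any claim that something is new, unique, unknown or untested is made for them only; others in the source may bear on it.

Compound 3 `O=C(COCc1c(-c2ccccc2)no[n+]1[O-])Nc1ccc(C(=O)/C=C/c2ccc(Cl)cc2)cc1` in a functional assay on the whole organism (strain albino) for inhibition, with Rattus norvegicus as the target, read by paw edema, with stated times of 30 min and 3 h, at a dose of 100 mg/kg by the oral route (a lower number here means less inhibition, a higher number more inhibition at the dose given (going by the name of the read-out)), gives 66%, second highest of the three numbers. Nearest stands compound 2 `O=C(CO[N+](=O)[O-])Nc1ccc(C(=O)/C=C/c2ccc(Cl)cc2)cc1`, which in this assay gives 69%, a gap within the scatter, so no order between compound 2 and compound 3 is claimed. Furthest stands compound 1 `O=C(CBr)Nc1ccc(C(=O)/C=C/c2ccco2)cc1`, which in this assay gives 41%, a gap beyond the scatter; compound 1 and compound 3 differ in two places, so no single step is drawn from them. Compound 4 `O=C(COCc1c(-c2ccccc2)no[n+]1[O-])Nc1ccc(C(=O)/C=C/c2ccco2)cc1` is not yet measured. The change from compound 3 is furan-2-yl in place of 4-chlorophenyl on a double-bonded chain carbon bound to a double-bonded chain carbon. Compound 1 carries the same furan-2-yl and stands lowest, but with another side chain, so a drop is expected only with caution. The expected step of a number 14 percentage points lower from compound 3 to compound 4 (beyond the scatter) is a moderate fall. Compound 4 is estimated at 52%, within 36% to 66%.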

Compound 4, a percentage reported as inhibition, in the whole organism at one dose (the size of the read-out at that dose, not a potency): 59%
Beside the measured number, compound 4's estimate is 7 percentage points below it; low and high end bracket the measured number.
By their numbers in this assay, from the lowest: compound 1; then compounds 4, 3 and 2 (each within the scatter of the next).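

In this assay, furan-2-yl in place of 4-chlorophenyl on a double-bonded chain carbon bound to a double-bonded chain carbon gives a number 7 percentage points lower from compound 3 to compound 4 (within the scatter), so this position accepts the five-membered ring with no change read beyond the scatter. Both carry furan-2-yl, yet compound 1 gives 41% and compound 4 gives 59%, so furan-2-yl alone does not set the low number. No measurement at hand accounts for this result.

Open, going by these compounds, is whether a 4-(dimethylamino)phenyl group at this place holds the number. Also open, on these data alone, is how furan-2-yl reads with the nitrate ester side chain.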